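Methylsulfonyl in place of (dimethylamino)methyl: expected clearance

This account rests on a few compounds, and the source may have more. Where it says the series, first, only, none or still open, it means among the compounds named here.

Compound 1, `CCn1c([C@@H](C)NS(=O)(=O)c2ccc(Cl)cc2)nc2ccc(C(F)(F)F)cc21`, gives > 100 mL.min-1.g-1 in an ADME assay (liver) for metabolic stability, with Liver microsome (Homo sapiens) as the target, read by LC-MS, using microsomes and NADPH, with a stated time of 5 min, at 37 degrees C (on this read-out higher numbers stand for fast clearance and lower numbers for slow clearance), which is a limit of the assay and not a number. Compound 2, `CCn1c([C@@H](C)NS(=O)(=O)c2ccc(Cl)cc2)nc2ccc(CO)cc21`, gives 84 mL.min-1.g-1 in this assay. Compound 3, `CCn1c([C@@H](C)NS(=O)(=O)c2ccc(Cl)cc2)nc2ccc(CN(C)C)cc21`, gives 30 mL.min-1.g-1, the lower of the two actual numbers in the set.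

Compound 4, `CCn1c([C@@H](C)NS(=O)(=O)c2ccc(Cl)cc2)nc2ccc(S(C)(=O)=O)cc21`, carries methylsulfonyl in place of (dimethylamino)methyl on an aromatic carbon.

Within the data shown here, no measured compound carries methylsulfonyl, so the guide is what the other groups at this place show. The measured steps are an at least 1.1-fold lower number from compound 1 to compound 2 (0.07 log units; that floor lies within the scatter), an at least 3.3-fold lower number from compound 1 to compound 3 (0.52 log units; beyond the scatter) and a 2.8-fold lower number from compound 2 to compound 3 (0.45 log units; beyond the scatter). The steps from compound 1 are floors only, given (the limit of > 100 mL.min-1.g-1 in this assay, at which 1 of the 3 values shown sits). In these three compounds, only the (dimethylamino)methyl group gives a number this low, and none goes against that. A modest move upward on leaving it is therefore expected, of roughly the size of a 2.8-fold lower number from compound 2 to compound 3 (0.45 log units; beyond the scatter).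

Expected in this assay is a 2.2-fold higher number from compound 3 to compound 4 (0.34 log units; beyond the scatter). For compound 4 the estimated value is 65 mL.min-1.g-1, with an expected range of 28 mL.min-1.g-1 to 100 mL.min-1.g-1.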

Compound 4, intrinsic clearance in microsomes: < 5 mL.min-1.g-1
Compound 4: a limit, no number (the forecaster's own chance of this, stated with the estimate: 15%); middle value at least 13-fold (1.11 log units) from the limit.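

In this assay compound 4 stands at a limit of the assay, not at a number: the limit of < 5 mL.min-1.g-1 in this assay, at which 1 of the 4 values shown sits.

On this aromatic carbon, methylsulfonyl gives the lowest clearance reading of the four compounds, with an at least 6.0-fold lower number from compound 3 to compound 4 (0.77 log units; beyond the scatter), an at least 16-fold lower number from compound 2 to compound 4 (1.22 log units; beyond the scatter) and an at least 20-fold lower number from compound 1 to compound 4 (1.30 log units; beyond the scatter). Among these compounds, the (dimethylamino)methyl group is thus not the only group here that lowers the number, and the group without nitrogen goes further, although the two have the same heavy-atom count and neither carries a net charge.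

Compound 1 also stands at a limit, so the full size of these steps stays open: the limit of > 100 mL.min-1.g-1 in this assay, at which 1 of the 4 values shown sits.

As far as these compounds go, whether a nitrile, a carboxylic acid or ethylsulfonyl at this place would read as low as methylsulfonyl also stays open.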